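Tosyl Piperidine Analogues and Chain Lengthening in WiDr Cells

The source may hold more compounds than are shown below. What is called first, only, known or untested is meant among the compounds shown, and "the series" means these compounds.

The study compares four sulfonamides, three of them measured in a functional assay on WiDr cells (Homo sapiens) for antiproliferative activity, read by sulforhodamine B assay, with a stated time of 48 h (a lower number here means a stronger inhibitor of growth, a higher number a weaker inhibitor of growth), and one still to be tested. Compound 1, with the structure `Cc1ccc(S(=O)(=O)N2CC[C@@H](Cl)C[C@@H]2CC(C)C)cc1`, gives 22000 nM in this assay. Compound 2, with the structure `CCCCCCC[C@H]1C[C@H](Cl)CCN1S(=O)(=O)c1ccc(C)cc1`, gives 54000 nM. The two share a saturated core and differ only by hexyl in place of isopropyl on a saturated chain carbon bound to a saturated ring carbon; that change produced a 2.5-fold higher number from compound 1 to compound 2 (0.39 log units; beyond the scatter), a modest step beyond the scatter.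

Compound 3, with the structure `Cc1ccc(S(=O)(=O)N2CCC(Br)=CC2CC(C)C)cc1`, gives 16000 nM. Its core carries a ring double bond and a bromine where compound 1 carries chlorine, and the difference between the two cores is not broken down here. Against compound 1 its value lies within the scatter, so no order between them can be claimed; against compound 2 it reads lower by a margin beyond the scatter.

Compound 4, with the structure `CCCCCCCC1C=C(Br)CCN1S(=O)(=O)c1ccc(C)cc1`, has not yet been measured. It differs from compound 3 by hexyl in place of isopropyl on a saturated chain carbon bound to a saturated ring carbon, the same change that separates compound 2 from compound 1, made at the same kind of position. Because of a 2.5-fold higher number from compound 1 to compound 2 (0.39 log units; beyond the scatter), compound 4 is expected to show the same direction of movement, with the step of a 2.5-fold higher number from compound 3 to compound 4 (0.40 log units; beyond the scatter) estimated. The estimate for compound 4 is 40000 nM, expected to fall between 20000 nM and 90000 nM.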

Compound 4, concentration for 50% growth inhibition: 40000 nM
For compound 4 middle estimate and measured number coincide at the digits printed, and the stated range covers the measured number.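

In this assay, hexyl in place of isopropyl on a saturated chain carbon bound to a saturated ring carbon gives a 2.5-fold higher number from compound 3 to compound 4 (0.40 log units; beyond the scatter), so the change moves the number in the same direction on the core of compound 3 as on the core of compound 1. Going by these compounds alone, the two steps match in size, with the gap between them within the scatter: the same change on two cores in this assay, a 2.5-fold higher number (0.39 log units; beyond the scatter) from compound 1 to compound 2 and a 2.5-fold higher number (0.40 log units; beyond the scatter) from compound 3 to compound 4, 1.0-fold (0.01 log units) apart, within the scatter of two such steps This shows the change carrying over between these two cores with a modest effect of similar size, but it rests on only two pairs and one exchange of groups, so it does not show that the same step would appear on any other core, nor does it explain why the number rises.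

The compounds shown leave open how the number follows chain length between and beyond these two groups, for instance with a butyl or a decyl chain, and whether an amine or a carboxylic acid in place of hexyl would fit the same trend. They also leave open how much of the difference between the cores belongs to the ring double bond and how much to bromine in place of chlorine, which change together from compound 1 to compound 3.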